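Cytotoxicity notes on a sulfamoylphenyl pyrazoline series

A few compounds are considered here, and "the series" means these few. Any claim that something is new, unique, unknown or untested is made for them only; others in the source may bear on it.

Three compounds of one shared core are measured in an ADME assay on MT4 cells (Homo sapiens) for cytotoxicity, read by MTT assay, with a stated time of 96 h; on this read-out lower numbers stand for higher toxicity in this test and higher numbers for lower toxicity in this test. Compound 1 `NS(=O)(=O)c1ccc(N2N=C(c3ccccc3)CC2c2ccccc2F)cc1` gives 42000 nM in this assay. Compound 2 `Cc1ccc(C2CC(c3ccccc3)=NN2c2ccc(S(N)(=O)=O)cc2)cc1` gives 40000 nM in this assay. Compound 3 `Cc1ccc(C2CC(c3ccc(OCc4ccccc4)cc3)=NN2c2ccc(S(N)(=O)=O)cc2)cc1` gives 35000 nM in this assay. The three numbers sit close together, and none of the differences between them stands out from the usual scatter.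

Two structural changes connect the measured compounds. The first, (2-fluorophenyl in place of 4-methylphenyl on a saturated ring carbon), made a 1.1-fold higher number from compound 2 to compound 1 (0.02 log units; within the scatter). The second, (benzyloxy in place of hydrogen on an aromatic carbon), made a 1.1-fold lower number from compound 2 to compound 3 (0.06 log units; within the scatter). This second change is also what separates the core of compound 2 from the core of compound 3.

Compound 4 `NS(=O)(=O)c1ccc(N2N=C(c3ccc(OCc4ccccc4)cc3)CC2c2ccccc2F)cc1` is not yet measured. It differs from compound 3 by 2-fluorophenyl in place of 4-methylphenyl on a saturated ring carbon. Within the data shown here, this is the same kind of change as the one from compound 2 to compound 1, but the surroundings of the place are not identical: in compound 3 the saturated ring carbon is next to the ring atom that bears a 4-sulfamoylphenyl group and two ring bonds from the ring atom that bears a large group, whereas in compound 2 it is next to the ring atom that bears a large group and two ring bonds from the ring atom that bears a phenyl group (6 heavy atoms).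

Given that the earlier step made a 1.1-fold higher number from compound 2 to compound 1 (0.02 log units; within the scatter), the step from compound 3 to compound 4 is expected to be small as well, a 1.0-fold higher number from compound 3 to compound 4 (0.01 log units; within the scatter). Compound 4 is thus estimated at 36000 nM in this assay, with the range 20000 nM to 65000 nM expected to cover it.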

Compound 4, half-maximal cytotoxic concentration: 39000 nM
Beside the measured number, compound 4's estimate is 1.1-fold (0.03 log units) below it; the measured number falls inside the stated range.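

In this assay, 2-fluorophenyl in place of 4-methylphenyl on the saturated ring carbon gives a 1.1-fold higher number from compound 3 to compound 4 (0.05 log units; within the scatter), and this reading on the benzyloxy-bearing core agrees with the earlier one on the core without benzyloxy: the same change on two cores in this assay, a 1.1-fold higher number (0.02 log units; within the scatter) from compound 2 to compound 1 and a 1.1-fold higher number (0.05 log units; within the scatter) from compound 3 to compound 4, 1.1-fold (0.03 log units) apart, within the scatter of two such steps

Benzyloxy in place of hydrogen on an aromatic carbon, read on the core that carries 2-fluorophenyl, gives a 1.1-fold lower number from compound 1 to compound 4 (0.03 log units; within the scatter), and it agrees with its earlier reading in the same way: the same change on two cores in this assay, a 1.1-fold lower number (0.06 log units; within the scatter) from compound 2 to compound 3 and a 1.1-fold lower number (0.03 log units; within the scatter) from compound 1 to compound 4, 1.1-fold (0.03 log units) apart, within the scatter of two such steps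

Among these compounds, both changes therefore carry between these two cores with no gap beyond the scatter, but every step here is itself within the scatter, so the agreement shows only that neither change measurably moves the number on these cores, and it does not show that a change with a clear effect would carry over, or that either change would behave the same on any other core.

Going by these compounds, whether an amine or a carboxylic acid in place of the benzyloxy group, or a longer chain there, would leave the number where it stands remains open. All four compounds also carry the 4-sulfamoylphenyl group, so what this group contributes to the number cannot be told from them.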